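This account rests on a few compounds, and the source may have more. Where it says the series, first, only, none or still open, it means among the compounds named here.

Compound 3 `COc1ccccc1Oc1ccc2c(NCCCNCc3ccco3)ccnc2c1` was measured in a physicochemical assay for solubility, with a stated time of 18 h, at pH 7.4 (a lower number here means a less soluble compound, a higher number a more soluble compound), and gives 14500 nM. Among the three measured compounds it stands second highest: compound 1 `COc1ccc(-c2ccc3c(NCCCNCc4cccc(OC)c4O)ccnc3c2)cc1` gives 32000 nM in this assay, and compound 2 `COc1cccc(CNCCCNc2ccnc3cc(CCC(C)C)ccc23)c1O` gives 4200 nM, so compound 3 lies between them, nearer to compound 1.

Compound 4 `COc1ccccc1Oc1ccc2c(NCCCNCc3cccc(OC)c3O)ccnc2c1` differs from compound 3 by 2-hydroxy-3-methoxyphenyl in place of furan-2-yl on a saturated chain carbon bound to an amine nitrogen. For the measured compounds named here, the only single-point step among the measured compounds, a 7.6-fold lower number from compound 1 to compound 2 (0.88 log units; beyond the scatter), concerns the group on the aromatic carbon of the shared core and does not touch the chain end, so it says nothing directly about this change. Compound 1, which carries the same 2-hydroxy-3-methoxybenzyl group as compound 4 but a different group on the core, gives the highest number of the three, which offers only weak guidance. Going by the values given here, with no measured step bearing on the change, a step of a 1.4-fold higher number from compound 3 to compound 4 (0.14 log units; within the scatter) is expected, in other words none beyond the scatter. Compound 4 is therefore expected to give about 20000 nM in this assay, within a range of 7000 nM to 55000 nM.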

Compound 4, solubility: 14500 nM
For compound 4 the middle estimate is 1.4-fold (0.14 log units) above the measured one; the range from low to high includes it.
By their numbers in this assay, from the lowest: compound 2; then compounds 3 and 4 (each within the scatter of the next); then compound 1.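

In this assay, exchanging furan-2-yl for 2-hydroxy-3-methoxyphenyl on a saturated chain carbon bound to an amine nitrogen gives no change at the digits printed from compound 3 to compound 4 (within the scatter) with 2-methoxyphenoxy on the shared core, so these two groups cannot be told apart at this position. With the 2-hydroxy-3-methoxybenzyl group held fixed, the group on the aromatic carbon does separate the compounds, with a 3.5-fold higher number from compound 2 to compound 4 (0.54 log units; beyond the scatter) for 2-methoxyphenoxy in place of isopentyl and a 2.2-fold lower number from compound 1 to compound 4 (0.34 log units; beyond the scatter) for 2-methoxyphenoxy in place of 4-methoxyphenyl. No measurement shown here accounts for either result.

Furan-2-yl appears only with 2-methoxyphenoxy on the core, so it remains open whether the chain-end exchange would read the same with isopentyl or 4-methoxyphenyl there. Also open, on these data alone, is how a carboxylic acid or a piperidine at the chain end would read.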